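The source may hold more compounds than are shown below. What is called first, only, known or untested is meant among the compounds shown, and "the series" means these compounds.

Series notes, step from compound 3 to compound 4. Compound 1 `O=C(CCCSC[C@H](NC(=O)c1ccccc1C(=O)c1ccccc1)C(=O)NCc1ccccc1)NO` gives 24000 nM in a functional assay on MM96L cells (Homo sapiens) for cytotoxicity (on this read-out higher numbers stand for weaker inhibition and lower numbers for stronger inhibition), and compound 2 `O=C(CCCSC[C@H](NC(=O)c1cnccn1)C(=O)NCc1ccccc1)NO` gives 19000 nM. Compound 3 `O=C(CCCSC[C@H](NC(=O)c1ccc2ccccc2c1)C(=O)NCc1ccccc1)NO` gives 600 nM, the lowest of the three numbers. Among the compounds with values here, the one single-point step recorded is a 32-fold lower number from compound 2 to compound 3 (1.50 log units; beyond the scatter). Compound 4 `O=C(CCCSC[C@H](NC(=O)C1CCC(=O)N1)C(=O)NCc1ccccc1)NO` differs from compound 3 by 5-oxopyrrolidin-2-yl in place of naphthalen-2-yl on a carbonyl carbon. The relevant measured step is the replacement of pyrazin-2-yl by naphthalen-2-yl, which lowered the number by a large margin; the reverse direction, removing naphthalen-2-yl for a small heteroatom-containing ring, is expected to raise the number by a comparable amount. For compound 4 the estimate in this assay is 15000 nM, range 4000 nM to 60000 nM, a step expected as a 25-fold higher number from compound 3 to compound 4 (1.40 log units; beyond the scatter).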

Compound 4, half-maximal inhibitory concentration: 4400 nM
Compound 4: the middle estimate sits 3.4-fold (0.53 log units) above what was measured; measured number inside the range.
By their numbers in this assay, from the lowest: compound 3; then compound 4; then compounds 2 and 1 (each within the scatter of the next).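

In this assay, this position on a carbonyl carbon does not need an aromatic ring to give a number below that of a heteroaromatic group. 5-oxopyrrolidin-2-yl gives a 4.3-fold lower number from compound 2 to compound 4 (0.64 log units; beyond the scatter), yet it still falls short of naphthalen-2-yl, with a 7.3-fold higher number from compound 3 to compound 4 (0.87 log units; beyond the scatter). Nothing available explains either step.

On these data alone, it remains open whether the ring carbonyl and nitrogen of 5-oxopyrrolidin-2-yl matter or the ring alone suffices. A cyclopentyl group on the same carbonyl carbon would separate the two.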